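Adding One Methyl to the Methylamino Chain

A few compounds are considered here, and "the series" means these few. Any claim that something is new, unique, unknown or untested is made for them only; others in the source may bear on it.

In a functional assay on HCT-8 cells (Homo sapiens) for antiproliferative activity, read by MTT assay, with a stated time of 48 h (a lower number here means a stronger inhibitor, a higher number a weaker inhibitor), compound 1 (`COc1ccc(C(=O)c2ccc(OC)c3c2C=CC(C)(C)O3)c(NC(=O)CO)c1`) gives 630 nM, while compound 2 (`CNCC(=O)Nc1cc(OC)ccc1C(=O)c1ccc(OC)c2c1C=CC(C)(C)O2`) gives 3460 nM, the higher of the two numbers. For the measured compounds named here, the only measured step, a 5.5-fold higher number from compound 1 to compound 2 (0.74 log units; beyond the scatter), put methylamino in place of hydroxy. Compound 3 (`CCNCC(=O)Nc1cc(OC)ccc1C(=O)c1ccc(OC)c2c1C=CC(C)(C)O2`) turns methylamino into ethylamino: methyl in place of hydrogen on a saturated chain carbon bound to an amine nitrogen. The measured step also concerns the methylamino group but is a different change, so it is only a loose guide, and no step beyond the scatter is expected in this assay. The expected step is a 1.2-fold lower number from compound 2 to compound 3 (0.06 log units; within the scatter). Compound 3 is estimated at 3000 nM, with an expected range of 1200 nM to 7500 nM.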

Compound 3, half-maximal inhibitory concentration: 7890 nM
Estimate against measurement, compound 3: 2.6-fold (0.42 log units) below; the whole stated range lies below it.
By their numbers in this assay, from the lowest: compound 1; then compound 2; then compound 3.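

In this assay the change from methylamino to ethylamino gives a 2.3-fold higher number from compound 2 to compound 3 (0.36 log units; beyond the scatter), so a single added methyl on this saturated chain carbon bound to an amine nitrogen does register at this position. Replacing hydroxy with ethylamino gives a 13-fold higher number from compound 1 to compound 3 (1.10 log units; beyond the scatter), and across the three compounds the number rises from hydroxy through methylamino to ethylamino. Nothing available explains this rise. On these data alone, whether a longer chain such as propylamino would raise the number further remains open. So does how a dimethylamino group or a morpholine would compare with hydroxy.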